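Working notes: nitro in place of methyl

The source may report more compounds than this note shows. Statements on the series, on what has been measured and on what is new or still open speak of the compounds shown alone.

In a functional assay on HL-60 cells (Homo sapiens) for inhibition, read by CCK-8 assay, with a stated time of 48 h, tested at 20 uM (on this read-out lower numbers stand for less inhibition of growth and higher numbers for more inhibition of growth at the one concentration tested), compound 1 `N#C/C(=C\c1ccccc1OS(=O)(=O)c1ccc([N+](=O)[O-])cc1)C(=O)Nc1nnc(-c2cccs2)s1` gives 23% and compound 2 `Cc1ccc(S(=O)(=O)Oc2ccccc2/C=C(\C#N)C(=O)Nc2nnc(Cc3ccccc3)s2)cc1` gives 16%, two values within the usual scatter of each other. Compound 3 `N#C/C(=C\c1ccccc1OS(=O)(=O)c1ccc([N+](=O)[O-])cc1)C(=O)Nc1nnc(Cc2ccccc2)s1` differs from compound 2 in one place, with nitro in place of methyl on an aromatic carbon. Among the compounds with values here, no measured pair shows this change, so, starting from compound 2 at 16%, no shift beyond the scatter is expected in this assay. The expected step of a number 4 percentage points higher from compound 2 to compound 3 (within the scatter) is small and upward. For compound 3 the estimated value is 20%, with an expected range of 8% to 36%.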

Compound 3, percent growth inhibition at one concentration: 20%
Beside the measured number, compound 3's estimate shows no gap at the digits printed, within the range that was stated.
By their numbers in this assay, from the lowest: compounds 2, 3 and 1 (each within the scatter of the next).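

Nitro in place of methyl on the aromatic carbon, para to a large group, gives a number 4 percentage points higher from compound 2 to compound 3 (within the scatter) in this assay and is the first single-place change read at this position. Benzyl in place of thiophen-2-yl gives a number 3 percentage points lower from compound 1 to compound 3 (within the scatter) in this assay, so neither single-place change separates the compounds at the one concentration tested. No evidence on any property bears on these two steps.

Going by these compounds, whether an amine or a carboxylic acid on that aromatic carbon would give a step beyond the scatter remains open. The same holds for a longer chain in place of benzyl.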